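Clearance of a methoxypyrazine amide, estimated from two neighbours

A few compounds are considered here, and "the series" means these few. Any claim that something is new, unique, unknown or untested is made for them only; others in the source may bear on it.

Measured in an ADME assay on the whole organism (strain Sprague-Dawley) for pharmacokinetics, with Rattus norvegicus as the target, read by LC-MS, using cassette dosing, at a dose of 0.5 mg/kg by the intravenous route; a lower number here means slower removal, a higher number faster removal of the compound:
- compound 1 `C[C@@]1(c2cc(NC(=O)c3cnc(C(F)F)cn3)ccc2F)C=C(CF)OC(N)=N1` gives 48.1 mL/min/kg
- compound 2 `C[C@@]1(c2cc(NC(=O)c3ccc(C#N)cn3)ccc2F)C=C(CF)OC(N)=N1` gives 16.8 mL/min/kg
- compound 3 `COc1cnc(C(=O)Nc2ccc(F)c([C@]3(C)C=C(CF)OC(N)=N3)c2)cn1` has not yet been measured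

Of the two measured compounds, compound 2 stands lowest at 16.8 mL/min/kg. Compound 3 carries 5-methoxypyrazin-2-yl in place of 5-cyanopyridin-2-yl on a carbonyl carbon.

For the measured compounds named here, only one measured step bears on this change, and only in part. That step is a 2.9-fold lower number from compound 1 to compound 2 (0.46 log units; beyond the scatter), and it brought in the same 5-cyanopyridin-2-yl that now leaves, in place of 5-(difluoromethyl)pyrazin-2-yl. Compound 3 returns to a pyrazin-2-yl group, but with a different group on it, and the effect of that group has not been measured. In this assay, a move back up of about the same modest size is therefore expected, with no great confidence. The expected move is estimated as a 2.1-fold higher number from compound 2 to compound 3 (0.33 log units; beyond the scatter). For compound 3 the estimated value is 36 mL/min/kg, with an expected range of 18 mL/min/kg to 70 mL/min/kg.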

Compound 3, clearance: 64.9 mL/min/kg
Estimate against measurement, compound 3: 1.8-fold (0.26 log units) below; the measured number falls inside the stated range.
By their numbers in this assay, from the lowest: compound 2; then compounds 1 and 3 (each within the scatter of the next).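

Compound 2 remains the only one of the three with a clearly lower number in this assay: a 3.9-fold higher number from compound 2 to compound 3 (0.59 log units; beyond the scatter), so its advantage over compound 1 does not carry over to a pyrazin-2-yl group with a different substituent. The second new step, a 1.3-fold higher number from compound 1 to compound 3 (0.13 log units; within the scatter), shows that methoxy in place of difluoromethyl on an aromatic carbon cannot be told apart from no change here, which means that, across these two groups, the identity of the substituent on the pyrazin-2-yl group makes no discernible difference to the read-out. Nothing in the data shown explains why the numbers differ in this way, as no supporting measurement bears on it.

Both steps away from compound 2 change the ring and its substituent together, so the compounds shown cannot separate the contribution of the pyridin-2-yl ring from that of the nitrile. On these data alone, a nitrile carried on the pyrazin-2-yl group, or a methoxy group carried on the pyridin-2-yl group, would pull these two apart, and whether an amine at that place would behave like methoxy and difluoromethyl also stays open.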